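This account rests on a few compounds, and the source may have more. Where it says the series, first, only, none or still open, it means among the compounds named here.

In a functional assay on NCI-H1299 cells (Homo sapiens), read by flow cytometry (a lower number here means that less compound is needed, a higher number that more compound is needed for the effect), the measured compounds are:
compound 1 `N#Cc1ncc2nc1OCC/C=C\COc1ccc(O)cc1NC(=O)N2` gives > 10000 nM (a limit)
compound 2 `CCOc1ccc2c(c1)NC(=O)Nc1cnc(C#N)c(n1)OCC/C=C\CO2` gives > 10000 nM (a limit)
compound 3 `N#Cc1ncc2nc1OCC/C=C\COc1ccc(Br)cc1NC(=O)N2` gives > 10000 nM (a limit)

None of these three entries is a number. Compound 1 stands at the limit of > 10000 nM in this assay, at which 3 of the 3 values shown sit, so its place is fixed only by that limit, as are those of the other two.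

Compound 4 `Cc1ccc2c(c1)NC(=O)Nc1cnc(C#N)c(n1)OCC/C=C\CO2` has not yet been measured. It differs from compound 1 by methyl in place of hydroxy on an aromatic carbon.

The closest measured step is a step that the two limits leave unreadable from compound 1 to compound 3, which is bromo in place of hydroxy on an aromatic carbon. Two further steps bear on the change, a step that the two limits leave unreadable from compound 1 to compound 2 and a step that the two limits leave unreadable from compound 2 to compound 3. The limits leave all three without a readable size or direction.

Going by the values given here, the only guide is therefore that hydroxy, ethoxy and bromo in compounds 1, 2 and 3 all end at the same limit, and no pattern reaches beyond them. In this assay, no step beyond the scatter is expected, and a result at the limit again seems likely. The estimated step is a number no higher from compound 1 to compound 4 (the limit leaves the size open). For compound 4 the estimated value is 10000 nM, with an expected range from 3000 nM to 30000 nM.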

Compound 4, half-maximal effective concentration: > 10000 nM
Compound 4: only a limit was reported (the forecaster's own chance of this, stated with the estimate: 75%); the middle value lies on the limit itself.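

In this assay compound 4 gives > 10000 nM, a limit and not a number. Its steps from compound 1, compound 2 and compound 3 cannot be read, as all four compounds end at the same limit: the limit of > 10000 nM in this assay, at which 4 of the 4 values shown sit.

The compounds shown leave open whether any group on this aromatic carbon changes the effect at all.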